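A few compounds are considered here, and "the series" means these few. Any claim that something is new, unique, unknown or untested is made for them only; others in the source may bear on it.

Series read in a functional assay on MIA PaCa-2 cells (Homo sapiens) for antiproliferative activity, read by sulforhodamine B assay, with a stated time of 48 h; a higher number here means a weaker inhibitor, a lower number a stronger inhibitor:

- compound 1 `COc1cc(OC)c2sc(-c3ccc(N/C=C\C(=O)c4ccc(OC)c(O)c4)cc3)nc2c1`: 11600 nM
- compound 2 `COc1ccc2nc(-c3ccc(N/C=C\C(=O)c4cc(OC)c(OC)c(OC)c4)c(C)c3)sc2c1`: 10000 nM
- compound 3 `COc1cc(OC)c2sc(-c3ccc(N/C=C\C(=O)c4ccc(OC)c([N+](=O)[O-])c4)cc3)nc2c1`: 2900 nM

Compound 2 lies within the scatter of compound 1, so the two cannot be ordered. Both numbers sit on the weak side of the small set, and compound 3 shows the lowest number of the three, beyond the scatter from each of them.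

The next compound is compound 4 `COc1ccc2nc(-c3ccc(N/C=C\C(=O)c4cc(OC)c(OC)c(OC)c4)cc3)sc2c1`, which differs from compound 2 by hydrogen in place of methyl on an aromatic carbon. Within the data shown here, no measured pair isolates this change. Among the measured compounds shown here, the only measured step, a 4.0-fold lower number from compound 1 to compound 3 (0.60 log units; beyond the scatter), is nitro in place of hydroxy on an aromatic carbon. That is a different exchange at a different place in the molecule, so it bears on the present case only loosely. It shows that a single exchange in this series can produce a modest move, and it gives no direction for losing a methyl.

In this assay, no step beyond the scatter is therefore expected, with a slight lean towards a lower number held only weakly. The expected step is a 1.3-fold lower number from compound 2 to compound 4 (0.10 log units; within the scatter). For compound 4 the estimated value is 8000 nM, with an expected range of 3000 nM to 20000 nM.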

Compound 4, half-maximal inhibitory concentration: 31100 nM
For compound 4 the middle estimate is 3.9-fold (0.59 log units) below the measured one; the measured number lies above the stated range.
By their numbers in this assay, from the lowest: compound 3; then compounds 2 and 1 (each within the scatter of the next); then compound 4.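

Position notes: the central six-membered aromatic ring carbon ortho to a large group and meta to a 6-methoxy-1,3-benzothiazol-2-yl group is now shown to respond in this assay, with hydrogen in place of methyl giving a 3.1-fold higher number from compound 2 to compound 4 (0.49 log units; beyond the scatter). Among these compounds, the earlier step involved a substituent on the aryl ketone ring, so this is the first evidence that a change elsewhere in the molecule, here the loss of one heavy atom, can also move the number beyond the scatter, and the direction favours the methyl-bearing compound 2 over compound 4. No measurement shown here explains this shift.

Still open, as far as these compounds go, is whether the gain belongs to methyl specifically or would extend to other groups at this carbon, such as ethyl, chlorine or an amine. From the compounds shown here alone, it is also open whether the same methyl exchange would move the number similarly with the other substitution patterns of the series, such as the nitro-bearing aryl ketone and dimethoxy-substituted core of compound 3.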